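Solubility at the limit and a new aniline substituent

The source may report more compounds than this note shows. Statements on the series, on what has been measured and on what is new or still open speak of the compounds shown alone.

Compound 1, `CNC(=O)c1cc(Oc2ccc3nc(Nc4cccc(C(C)(C)C)c4)ccc3c2)ccn1`, in a physicochemical assay for solubility, at pH 7 (on this read-out higher numbers stand for higher solubility and lower numbers for lower solubility), gives < 1000 nM, a limit of the assay.
Compound 2, `CCc1ccccc1Nc1ncc2cc(Oc3ccnc(C(=O)NC)c3)ccc2n1`, in this assay gives < 1000 nM, a limit of the assay.
Compound 3, `CNC(=O)c1cc(Oc2ccc3nc(Nc4cccc(OC(F)(F)F)c4)ncc3c2)ccn1`, in this assay gives < 1000 nM, a limit of the assay.

Compound 2 therefore stands only at a limit, and the two other values shown are limits as well; none of the three is a number. For the measured compounds named here, the one measured change at the same position, a step that the two limits leave unreadable from compound 2 to compound 3, cannot be sized for this reason. (the limit of < 1000 nM in this assay, at which 3 of the 3 values shown sit).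

Compound 4, `CNC(=O)c1cc(Oc2ccc3nc(Nc4cccc(C(C)C)c4)ncc3c2)ccn1`, differs from compound 2 by 3-isopropylphenyl in place of 2-ethylphenyl on a nitrogen on an aromatic ring. Going by the values given here, no measured step gives a readable size for a change at this position, so no step beyond the scatter can be predicted, and the expectation rests on where compound 2 and the other compounds sit. Compound 4 is expected to give about 500 nM in this assay, most likely again reported as a limit, with a range from 100 nM to 2000 nM. The expected step is a step that the limit leaves unreadable from compound 2 to compound 4, which is no step beyond the scatter.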

Compound 4, solubility: < 1000 nM
Compound 4 was reported as a limit (the forecaster's own chance of this, stated with the estimate: 80%); the middle value lies beyond the limit too.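

Compound 4, like compound 2 and compound 3, is reported only as a limit, so its steps from those two compounds cannot be read: the limit of < 1000 nM in this assay, at which 4 of the 4 values shown sit. Going by these compounds, whether 2-ethylphenyl, 3-(trifluoromethoxy)phenyl and 3-isopropylphenyl differ at all in this assay stays open.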